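The compounds below may be only part of what the source reports. "The series", "measured", "known", "first", "only" and "open" are said of these compounds alone.

Working notes on the series: in a functional assay on HT cells (Homo sapiens) for antiproliferative activity, read by fluorescence, with a stated time of 72 h (a lower number here means a stronger inhibitor of growth, a higher number a weaker inhibitor of growth), compound 2 (`CC(C)c1n[nH]c2c(NCc3ccc(-c4ccccn4)cc3)nc(SCCn3ccnc3)nc12`) gives 155 nM, the lower of the two numbers so far, and compound 1 (`CC(C)c1n[nH]c2c(NCc3ccc(-c4ccccn4)cc3)nc(SC(CO)C(C)C)nc12`) gives 980 nM.

Compound 3 (`C=CCSc1nc(NCc2ccc(-c3ccccn3)cc2)c2[nH]nc(C(C)C)c2n1`) differs from compound 2 at one place: vinyl in place of (1H-imidazol-1-yl)methyl on a saturated chain carbon bound to a sulfur. Put another way, 2-(1H-imidazol-1-yl)ethyl becomes allyl.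

Among the compounds with values here, the only measured step bearing on this is a 6.3-fold lower number from compound 1 to compound 2 (0.80 log units; beyond the scatter), a modest one at the same sulfur. It is a different exchange, and no allyl comparison exists, so it serves only as a guide to size. Compound 3 gives up the (1H-imidazol-1-yl) group, which compound 1 also lacks. A modest move to a higher number is therefore expected in this assay, smaller than that measured step. The expected step is a 2.6-fold higher number from compound 2 to compound 3 (0.41 log units; beyond the scatter). For compound 3 the estimate is 400 nM, with an expected range of 130 nM to 1200 nM.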

Compound 3, concentration for 50% growth inhibition: 1010 nM
For compound 3 the middle estimate is 2.5-fold (0.40 log units) below the measured one, and the stated range covers the measured number.
By their numbers in this assay, from the lowest: compound 2; then compounds 1 and 3 (each within the scatter of the next).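

In this assay, allyl in place of 2-(1H-imidazol-1-yl)ethyl on the sulfur gives a 6.5-fold higher number from compound 2 to compound 3 (0.81 log units; beyond the scatter), so the lower number of compound 2 now stands against two different groups that lack the imidazole ring. Those two groups do not separate, with a 1.0-fold higher number from compound 1 to compound 3 (0.01 log units; within the scatter), so at this sulfur the small allyl and the larger, hydroxyl-bearing 1-(hydroxymethyl)-2-methylpropyl read alike in this series. No measurement is available that explains the difference between compound 2 and the other two compounds.

The compounds shown leave open whether the imidazole ring itself matters or whether another nitrogen-bearing end group, such as a 2-(dimethylamino)ethyl or a 2-(1H-pyrazol-1-yl)ethyl, would do the same. They also leave open how a longer chain, such as 3-(1H-imidazol-1-yl)propyl, would read.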